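Swapping Chloro for Nitro: Expectation for Compound 4

This account rests on a few compounds, and the source may have more. Where it says the series, first, only, none or still open, it means among the compounds named here.

Compound 1, `O=C(CCc1nnc(-c2ccccc2)o1)c1ccccc1`: 18.7%
Compound 2, `O=C(CCc1nnc(-c2ccccc2Cl)o1)c1ccccc1`: 26.9%
Compound 3, `O=C(CCc1nnc(-c2ccc(Cl)cc2)o1)c1ccccc1`: 42%

Three compounds share one core and differ only at a single aromatic carbon. In a functional assay on the whole organism (strain Wistar) for inhibition, with Rattus norvegicus as the target, with stated times of 30 min and 2 h, at a dose of 20 mg/kg by the oral route (a lower number here means less inhibition, a higher number more inhibition at the dose given (going by the name of the read-out)), compound 1 gives 18.7%, compound 2 gives 26.9% and compound 3 gives 42%. The step of a number 8.2 percentage points higher from compound 1 to compound 2 (within the scatter) is small, whereas a number 23.3 percentage points higher from compound 1 to compound 3 (beyond the scatter) and a number 15.1 percentage points higher from compound 2 to compound 3 (beyond the scatter) are both beyond the scatter. Compound 3 thus stands highest of the three, with compound 2 nearest and compound 1 furthest.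

Compound 4, `O=C(CCc1nnc(-c2ccc([N+](=O)[O-])cc2)o1)c1ccccc1`, is not yet measured. It differs from compound 3 in one place: nitro in place of chloro on an aromatic carbon. Among the compounds with values here, none of the measured steps involves a nitro group; the only steps known concern the introduction and placement of chloro, so they bear on this change only by showing that the group at this position can move the read-out by a modest amount. The data give no direction for a nitro group. The expectation is therefore a number near that of compound 3, with a step in this assay that may fall within the scatter or be modest in either direction.

Compound 4 is estimated at 40%, with a range from 22% to 58%, which means an expected step of a number 2 percentage points lower from compound 3 to compound 4 (within the scatter).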

Compound 4, a percentage reported as inhibition, in the whole organism at one dose (the size of the read-out at that dose, not a potency): 40.9%
Compound 4: middle estimate off by 0.9 percentage points, on the low side; the range from low to high includes it.
By their numbers in this assay, from the lowest: compounds 1 and 2 (each within the scatter of the next); then compounds 4 and 3 (each within the scatter of the next).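

Within the data shown here, at this place, para to a large group, chloro was the only group seen so far, and nitro is a different kind of group: it has more heavy atoms and carries hydrogen-bond acceptors, whereas chloro has none. Even so, in this assay the exchange gives a number 1.1 percentage points lower from compound 3 to compound 4 (within the scatter), so this change leaves the read-out indistinguishable from that of the chloro compound. Set against the compound with hydrogen at this place, nitro gives a number 22.2 percentage points higher from compound 1 to compound 4 (beyond the scatter), which shows that the gain seen with chloro at this place is not confined to chloro; nothing measured here explains why these two groups read alike.

The compounds shown leave open whether the gain holds for groups of another kind at this place, such as an amine, a carboxylic acid or a longer chain. They also leave open how nitro would behave at the place that chloro occupies in compound 2, and whether changes to the ring on the carbonyl side of the shared core would shift the read-out as well.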